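Propylsulfanyl in place of (3-bromobenzyl)sulfanyl on the core

The source may report more compounds than this note shows. Statements on the series, on what has been measured and on what is new or still open speak of the compounds shown alone.

Within the data shown here, compound 1 `Cc1cc(Nc2cc(-c3ccccc3)[nH]n2)n2nc(SCc3cccc(Br)c3)nc2n1` gives 8900 nM in a functional assay on PC-9 cells (Homo sapiens) for inhibition, read by MTT assay, with a stated time of 72 h (on this read-out higher numbers stand for weaker inhibition and lower numbers for stronger inhibition), and is the only compound of the series with a number so far. Compound 2 `CCCCCc1c(C)nc2nc(SCc3ccc(Cl)cc3)nn2c1Nc1cc(-c2ccccc2)[nH]n1` gives > 50000 nM in this assay, which is a limit of the assay rather than a number, and so sits at the limit of > 50000 nM in this assay, at which 1 of the 2 values shown sits. Among the measured compounds shown here, no two measured compounds differ in a single place, so no measured step is available to lean on.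

Compound 3 `CCCSc1nc2nc(C)cc(Nc3cc(-c4ccccc4)[nH]n3)n2n1` differs from compound 1 in one place: ethyl in place of 3-bromophenyl on a saturated chain carbon bound to a sulfur; cut one bond further out this reads 3-bromobenzyl to propyl, or (3-bromobenzyl)sulfanyl to propylsulfanyl. The one six-membered aromatic ring of carbon only, with its bromine, is gone, and a two-carbon chain stands on the saturated chain carbon bound to the sulfur instead. Without a measured step in hand, the expected step of a 2.8-fold higher number from compound 1 to compound 3 (0.45 log units; beyond the scatter) is toward weaker inhibition and beyond the scatter. Compound 3 is expected to give about 25000 nM in this assay, within a range from 8000 nM to 60000 nM, with a fair chance that only a limit is reported.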

Compound 3, half-maximal inhibitory concentration: > 50000 nM
Compound 3 ended at the assay's limit; the forecaster's own chance of this, stated with the estimate: 40%; middle value at least 2.0-fold (0.30 log units) from the limit.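

In this assay compound 3 gives > 50000 nM, which is a limit of the assay and not a number. Among these compounds, this provides the first measured one-place step at the sulfur substituent of the series: ethyl in place of 3-bromophenyl on a saturated chain carbon bound to a sulfur gives an at least 5.6-fold higher number from compound 1 to compound 3 (0.74 log units; beyond the scatter), so the 3-bromobenzyl group cannot be swapped for propyl here without a loss beyond the scatter, and the true size of that loss is bounded on one side only. Readings at the limit now make up most of the series: the limit of > 50000 nM in this assay, at which 2 of the 3 values shown sit.

On these data alone, how much of the step belongs to the bromine and how much to the aromatic ring remains open. Plain benzyl on the sulfur would separate the two, and a longer chain such as hexyl would test whether chain length alone matters.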